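Bromo to Trifluoromethyl in Two Matched Pairs

A few compounds are considered here, and "the series" means these few. Any claim that something is new, unique, unknown or untested is made for them only; others in the source may bear on it.

Compound 1 `O=C(CSc1nc(Nc2ccccc2)c2ccccc2n1)Nc1ccc(Br)cc1` and compound 2 `O=C(CSc1nc(Nc2ccccc2)c2ccccc2n1)Nc1ccc(C(F)(F)F)cc1` share one core. In a functional assay on NCI-H1975 cells (Homo sapiens) for inhibition, read by MTT assay, with a stated time of 72 h (on this read-out lower numbers stand for stronger inhibition and higher numbers for weaker inhibition), compound 1 gives 10600 nM, and compound 2 gives 11700 nM. The change between them, (trifluoromethyl in place of bromo on an aromatic carbon), made a 1.1-fold higher number from compound 1 to compound 2 (0.04 log units; within the scatter). Compound 3 `C=CC(=O)Nc1cccc(NC(=O)CSc2nc(Nc3ccc(Br)cc3)c3ccccc3n2)c1` has another core; the difference between the two cores is not broken down here. In this assay compound 3 gives 6280 nM, a number within the scatter of both compound 1 and compound 2. Compound 4 `C=CC(=O)Nc1cccc(NC(=O)CSc2nc(Nc3ccc(C(F)(F)F)cc3)c3ccccc3n2)c1` differs from compound 3 by trifluoromethyl in place of bromo on an aromatic carbon, the same change as in the measured pair. The expected step is a 1.1-fold higher number from compound 3 to compound 4 (0.04 log units; within the scatter), because a 1.1-fold higher number from compound 1 to compound 2 (0.04 log units; within the scatter) lay within the scatter. Compound 4 is therefore estimated in this assay at 6900 nM, with an expected range from 3500 nM to 14000 nM.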

Compound 4, half-maximal inhibitory concentration: 12900 nM
Beside the measured number, compound 4's estimate is 1.9-fold (0.27 log units) below it; the measured number falls inside the stated range.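

In this assay the change from 4-bromophenyl to 4-(trifluoromethyl)phenyl on the core of compound 3 gave a 2.1-fold higher number from compound 3 to compound 4 (0.31 log units; beyond the scatter) on that second core. Set beside the earlier pair, the two steps do not differ by more than two such steps would be expected to: the same change on two cores in this assay, a 1.1-fold higher number (0.04 log units; within the scatter) from compound 1 to compound 2 and a 2.1-fold higher number (0.31 log units; beyond the scatter) from compound 3 to compound 4, 1.9-fold (0.27 log units) apart, within the scatter of two such steps. This agrees with the change carrying over between these two cores, but two pairs give no rule for the whole series and cannot show whether the gap between the steps is real. The compounds shown leave open how an amine or a methoxy group in place of bromo would read in this assay and whether the step would hold with it.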